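The source may report more compounds than this note shows. Statements on the series, on what has been measured and on what is new or still open speak of the compounds shown alone.

Of the compounds shown here, three sharing one core have been measured in an assay on CHO cells for displacement of a labelled ligand from adenosine receptor A1 (Homo sapiens), read by scintillation counting, with a stated time of 90 min, tested at 1 uM, in the presence of a further agent that is not named here; on this read-out higher numbers stand for more inhibition at the one concentration tested (going by the name of the read-out) and lower numbers for less inhibition. Compound 1 `CCCn1c(=O)[nH]c2nc(-c3ccc(S(=O)(=O)N4CCN(c5ccc(F)cc5)CC4)cc3)[nH]c2c1=O` gives 14% in this assay. Compound 2 `CCCn1c(=O)[nH]c2nc(-c3ccc(S(=O)(=O)N4CCN(c5ccc(Cl)cc5F)CC4)cc3)[nH]c2c1=O` gives 9%. Compound 3 `CCCn1c(=O)[nH]c2nc(-c3ccc(S(=O)(=O)N4CCN(c5cccc(Cl)c5)CC4)cc3)[nH]c2c1=O` gives 21%, the highest of the three numbers; it sits a number 7 percentage points higher from compound 1 to compound 3 (within the scatter) and a number 12 percentage points higher from compound 2 to compound 3 (beyond the scatter), while the pair of compounds 1 and 2 shows a number 5 percentage points lower from compound 1 to compound 2 (within the scatter).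

Compound 4 `CCCn1c(=O)[nH]c2nc(-c3ccc(S(=O)(=O)N4CCN(c5cccc(F)c5)CC4)cc3)[nH]c2c1=O` is not yet measured. It differs from compound 3 by fluoro in place of chloro on an aromatic carbon, so the change is 3-chlorophenyl to 3-fluorophenyl. Going by the values given here, no measured step swaps chloro for fluoro at a fixed position; the nearest is the step from compound 1 to compound 3, which changes both halogen and position and stays within the scatter, and the step from compound 2 to compound 3 is only modest. On this basis no step beyond the scatter is expected, with compound 4 estimated at 17%, between 7% and 27%. The expected step is therefore a number 4 percentage points lower from compound 3 to compound 4 (within the scatter).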

Compound 4, a percentage reported as inhibition, at one concentration (the size of the read-out at that concentration, not a potency): 34%
The estimate for compound 4 lay 17 percentage points below the measured number, and the stated range ends below it.
By their numbers in this assay, from the lowest: compounds 2, 1 and 3 (each within the scatter of the next, the first and the last beyond it); then compound 4.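

In this assay, the change from chloro to fluoro on an aromatic carbon meta to a large group gives a number 13 percentage points higher from compound 3 to compound 4 (beyond the scatter), so the identity of the halogen at this fixed position can move the number beyond the scatter. With fluoro kept on the ring, the 3-fluorophenyl group gives a number 20 percentage points higher from compound 1 to compound 4 (beyond the scatter) against the 4-fluorophenyl group, and it gives a number 25 percentage points higher from compound 2 to compound 4 (beyond the scatter) against the 4-chloro-2-fluorophenyl group, which leaves compound 4 the highest of the four compounds in this series. No evidence is available that explains these steps.

The compounds shown leave open whether a methoxy group or a nitrile on the same aromatic carbon would read above or below fluoro. They also leave open how the inhibition seen for compound 4 at one concentration relates to its potency.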